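This account rests on a few compounds, and the source may have more. Where it says the series, first, only, none or still open, it means among the compounds named here.

Working notes on the series, values in a functional assay on T47D cells (Homo sapiens) for antiproliferative activity, read by MTT assay, with a stated time of 48 h; on this read-out higher numbers stand for weaker inhibition and lower numbers for stronger inhibition:

- compound 1 `COc1ccc(/C=N/c2c(C#N)ncn2Cc2ccc(F)cc2)cc1`: 9190 nM
- compound 2 `COc1cc(C2N=C(C(N)=O)c3ncn(-c4ccc(F)cc4)c3N2)cc(OC)c1OC`: 10700 nM

Within the data shown here, compound 2, at 10700 nM, lies within the usual scatter of compound 1, at 9190 nM, so these two numbers set no order between the compounds.

Compound 3 `COc1ccc(C2N=C(C(N)=O)c3ncn(-c4ccc(F)cc4)c3N2)cc1OC` shares the core of compound 2 and has no value yet. The structural change is hydrogen in place of methoxy on an aromatic carbon, in words hydrogen in place of methoxy on an aromatic carbon. Among the measured compounds shown here, no measured pair isolates this change, so the data give neither a size nor a direction for it. In this assay no step beyond the scatter is expected, and neither direction is favoured. The estimate therefore stays anchored on compound 2 at 10700 nM, with a wide range to reflect how little the series shows so far. The expected outcome is a 1.1-fold lower number from compound 2 to compound 3 (0.03 log units; within the scatter). The estimate for compound 3 is 10000 nM, with an expected range of 3500 nM to 30000 nM.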

Compound 3, half-maximal inhibitory concentration: 9960 nM
Compound 3: the middle estimate sits 1.0-fold (0.00 log units) above what was measured, within the range that was stated.
By their numbers in this assay, from the lowest: compounds 1, 3 and 2 (each within the scatter of the next).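

In this assay, the pair gives the series its first reading of hydrogen in place of methoxy on an aromatic carbon, with a 1.1-fold lower number from compound 2 to compound 3 (0.03 log units; within the scatter). At this position, ortho to a methoxy group and meta to a large group, the methoxy can be exchanged for hydrogen with no separation of compound 3 from compound 2, so the value at this level does not depend on that methoxy in this one pair of compounds. No independent evidence bears on this result.

From the compounds shown here alone, the pair covers only methoxy and hydrogen on this carbon, so it remains open whether an amine, a hydroxy group or a longer chain such as butoxy would give a step beyond the scatter. The compounds shown also leave open whether the same exchange at the remaining methoxy groups on the ring would stay within the scatter, and whether the absence of a step here would hold on a core carrying a different group in place of the fluorophenyl.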